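A Methyl Group Joins the Chloro Compound

A few compounds are considered here, and "the series" means these few. Any claim that something is new, unique, unknown or untested is made for them only; others in the source may bear on it.

In a functional assay on MDA-MB-231 cells (Homo sapiens) for antiproliferative activity, with a stated time of 4 days (a higher number here means a weaker inhibitor, a lower number a stronger inhibitor), compound 1 `COc1ccc(-c2[nH]c3cc(F)ccc3c2C=O)cc1` gives 59 nM, and compound 2 `COc1ccc(-c2[nH]c3cc(Cl)ccc3c2C=O)cc1` gives 27 nM. Compound 2 thus holds the lower of the two numbers and is the stronger inhibitor of this pair. The next structure, compound 3 `COc1ccc(-c2[nH]c3cc(Cl)c(C)cc3c2C=O)cc1`, keeps everything in compound 2 and adds one feature, methyl in place of hydrogen on an aromatic carbon, ortho to a chloro group: methyl in place of hydrogen on an aromatic carbon.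

Going by the values given here, only one measured step can serve as a guide, and it is a 2.2-fold lower number from compound 1 to compound 2 (0.34 log units; beyond the scatter). That step is modest, and it exchanged one halogen for another on the same six-membered aromatic ring. Among the compounds with values here, it is therefore only indirect evidence, since no measured pair yet shows what adding a methyl group does. With so little to go on, a small step in this assay seems most likely, with no firm direction and possibly nothing beyond the scatter. The expected change is a 1.2-fold lower number from compound 2 to compound 3 (0.09 log units; within the scatter). For compound 3 the estimated value is 22 nM, with an expected range from 7 nM to 70 nM.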

Compound 3, half-maximal inhibitory concentration: 26 nM
For compound 3 the middle estimate is 1.2-fold (0.07 log units) below the measured one; low and high end bracket the measured number.
By their numbers in this assay, from the lowest: compounds 3 and 2 (each within the scatter of the next); then compound 1.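

In this assay, the new step reads a 1.0-fold lower number from compound 2 to compound 3 (0.02 log units; within the scatter), so compound 2 and compound 3 cannot be told apart. Going by these compounds alone, the earlier pair showed only one halogen swapped for another, whereas this pair gives the first direct reading of an added carbon group, here a methyl in place of hydrogen on an aromatic carbon, ortho to a chloro group. At this position, in this cell assay, the extra heavy atom is accepted without any loss or gain that stands clear of the scatter. No supporting measurement is available to explain why the methyl group makes no visible difference here.

From the compounds shown here alone, one small group at one position cannot show how much room this position really offers, so it remains open whether a longer chain such as propyl, or a group of another kind such as an amine or a hydroxyl, would give a similar reading. Going by these compounds, it is also open whether the same methyl group would behave alike with fluoro in place of chloro, as in compound 1.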